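The compounds below may be only part of what the source reports. "The series", "measured", "known", "first", "only" and "open" are said of these compounds alone.

Measured so far:
- Compound 1, `CSc1ccc(CNc2nc([SeH])nc3ccccc23)cc1`, in a functional assay on CCRF-CEM cells (Homo sapiens) for cytotoxicity, read by MTT assay, with a stated time of 72 h (on this read-out higher numbers stand for weaker inhibition of growth and lower numbers for stronger inhibition of growth), gives > 100000 nM, a limit of the assay.
- Compound 2, `CCCCC[Se]c1nc(NCc2ccc(SC)cc2)c2ccccc2n1`, gives 83900 nM.
- Compound 3, `CSc1nc(NCc2ccccc2)c2ccccc2n1`, gives > 100000 nM, again a limit.

Compound 3 thus stands at the limit rather than at a number, a position it shares with one other compound: the limit of > 100000 nM in this assay, at which 2 of the 3 values shown sit. Compound 4, `CSc1ccc(CNc2nc(SC)nc3ccccc23)cc1`, is compound 3 with methylsulfanyl in place of hydrogen on an aromatic carbon. The only measured step among these three compounds, an at least 1.1-fold lower number from compound 1 to compound 2 (0.07 log units; that floor lies within the scatter), concerns the selenium substituent and not the benzyl ring, so no measured step bears directly on the change from compound 3 to compound 4. Compound 1, which already carries the methylsulfanyl group on that ring, gives no number but a limit. Among the measured compounds shown here, with two of three values at the limit and the one measured step within the scatter, no step beyond the scatter is expected; a number no higher from compound 3 to compound 4 (the limit leaves the size open) is the expected change. Compound 4 is therefore estimated at 100000 nM, within a range from 50000 nM to 300000 nM, most likely reported again as a limit.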

Compound 4, concentration for total growth inhibition: > 100000 nM
Compound 4 gave a limit, no number; the forecaster's own chance of this, stated with the estimate: 65%; the middle value lies on the limit itself.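

Compound 4 also sits at a limit in this assay, so methylsulfanyl on this aromatic carbon, para to a large group, does not give a number where compound 3 gave none: the limit of > 100000 nM in this assay, at which 3 of the 4 values shown sit. The steps from compound 3 and from compound 1 to compound 4 cannot be read, as both ends of each are limits. Among the compounds shown here, the one step that can be read is an at least 1.1-fold higher number from compound 2 to compound 4 (0.07 log units; that floor lies within the scatter), so the smaller group on the core, with sulfur in place of selenium, gives no change that can be told from the scatter.

Going by these compounds, it remains open whether another group on this aromatic carbon, such as an amine or a carboxylic acid, would give a number rather than a limit. On these data alone, it also remains open whether pentyl on the sulfur of compound 4 would give a value near that of compound 2.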